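A few compounds are considered here, and "the series" means these few. Any claim that something is new, unique, unknown or untested is made for them only; others in the source may bear on it.

Measured compounds:
Compound 1, `CN(C)CCCCCn1c2c(c3ccccc31)C(=O)c1c[n+]([O-])c3ccccc3c1C2=O`: 210 nM
Compound 2, `O=C1c2c[n+]([O-])c3ccccc3c2C(=O)c2c1c1ccccc1n2CCN1CCCC1`: 410 nM

In a functional assay on A549 cells (Homo sapiens) for cytotoxicity, read by MTT assay, with a stated time of 72 h (on this read-out lower numbers stand for stronger inhibition and higher numbers for weaker inhibition), compound 1 gives 210 nM. Among the compounds with values here, only one other compound has a number here, compound 2, and the step of a 2.0-fold higher number from compound 1 to compound 2 (0.29 log units; within the scatter) means the two cannot be told apart; compound 1 therefore stands in a pair of numbers of about the same size. Compound 3 is `O=C1c2c[n+]([O-])c3ccccc3c2C(=O)c2c1c1ccccc1n2Cc1cn(C[C@@H](O)CO)nn1`. The change from compound 1 is 1-(2,3-dihydroxypropyl)-1H-1,2,3-triazol-4-yl in place of 4-(dimethylamino)butyl on a saturated chain carbon bound to an aromatic nitrogen. Within the data shown here, the single measured step, a 2.0-fold higher number from compound 1 to compound 2 (0.29 log units; within the scatter), swaps one amine-bearing chain for another and stays within the scatter, so it speaks only weakly to this change, in which the amine chain is lost altogether and a ring bearing two hydroxyl groups enters. Among the measured compounds shown here, with no closer precedent, a step beyond the scatter is expected in this assay, toward a higher number. Compound 3 is estimated at 800 nM, with a range from 250 nM to 3000 nM. That estimate for compound 3 means an expected step of a 3.8-fold higher number from compound 1 to compound 3 (0.58 log units; beyond the scatter).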

Compound 3, half-maximal inhibitory concentration: 390 nM
Estimate against measurement, compound 3: 2.1-fold (0.31 log units) above; the measured number falls inside the stated range.
By their numbers in this assay, from the lowest: compounds 1, 3 and 2 (each within the scatter of the next).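

In this assay, the position on a saturated chain carbon bound to an aromatic nitrogen tolerates a far larger change than the earlier pair showed: replacing 4-(dimethylamino)butyl with 1-(2,3-dihydroxypropyl)-1H-1,2,3-triazol-4-yl removes the amine and adds a ring, yet gives a 1.9-fold higher number from compound 1 to compound 3 (0.27 log units; within the scatter) and the comparison with the pyrrolidine compound gives a 1.1-fold lower number from compound 2 to compound 3 (0.02 log units; within the scatter) so all three compounds remain within the scatter of one another. Among these three compounds, then, an amine on this chain is not required for a number of this size. Nothing available here explains this result.

As far as these compounds go, it remains open whether a carboxylic acid or a plain hexyl chain at this place would give a similar number. The compounds shown also do not separate the contribution of the triazole ring from that of its two hydroxyl groups.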